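The compounds below may be only part of what the source reports. "The series", "measured", "known", "first", "only" and "open" are said of these compounds alone.

In an assay on isolated protein for inhibition of protein kinase C delta type (Homo sapiens), read by TR-FRET, with a stated time of 2 h (on this read-out lower numbers stand for stronger inhibition and higher numbers for weaker inhibition), compound 2 `CC1(C)[C@H](Nc2cc(NCc3cnccc3C(F)(F)F)ncc2C#N)C[C@H]1C(N)=O` gives 900 nM, the only number shown in the series. Compound 1 `N#Cc1cnc(NCc2cnccc2C(F)(F)F)cc1N[C@H]1C[C@H](O)C1` stops at a limit in this assay, reported as > 10000 nM (the limit of > 10000 nM in this assay, at which 1 of the 2 values shown sits). Among the compounds with values here, the single measured step, an at least 11-fold lower number from compound 1 to compound 2 (1.04 log units; beyond the scatter), concerns a change of substituent, not of configuration. Compound 3 `CC1(C)[C@@H](Nc2cc(NCc3cnccc3C(F)(F)F)ncc2C#N)C[C@@H]1C(N)=O` differs from compound 2 thus: the two compounds have the same atoms and bonds and differ only in configuration as drawn: 2 of 2 stereo elements differ (all stereocentres are inverted: mirror images); a stereocentre at a saturated ring carbon is drawn R in compound 2 and S in compound 3; a stereocentre at a saturated ring carbon is drawn R in compound 2 and S in compound 3. Within the data shown here, no measured step bears on mirror-image inversion, so the expected step of a 4.4-fold higher number from compound 2 to compound 3 (0.65 log units; beyond the scatter) rests on nothing firm; a weaker inhibition is expected for compound 3, with a wide range. Compound 3 is estimated at 4000 nM in this assay, between 900 nM and 20000 nM.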

Compound 3, half-maximal inhibitory concentration: > 10000 nM
Compound 3: a limit, no number (the forecaster's own chance of this, stated with the estimate: 30%); middle value at least 2.5-fold (0.39 log units) from the limit.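

With atoms and bonds unchanged, mirror-image inversion of the 3-carbamoyl-2,2-dimethylcyclobutyl group gives an at least 11-fold higher number from compound 2 to compound 3 (1.04 log units; beyond the scatter) in this assay, so the atoms of this group alone do not set the reading. Compound 3 gives > 10000 nM, a limit and not a number, and the step from compound 1 to compound 3 cannot be read, both values being limits. The configuration as drawn is all that separates the two readings: the fact that compounds 2 and 3 differ only in the configuration as drawn

Left open are the share of each stereocentre in this step, and whether a carboxylic acid or a primary amine in place of the carbamoyl group would keep a measurable number in the configuration of compound 2.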